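From 4-nitrophenyl to 2-nitrophenyl: working notes

The compounds below may be only part of what the source reports. "The series", "measured", "known", "first", "only" and "open" are said of these compounds alone.

compound 1 `CCC(/C=C(\COC(=O)c1ccccc1)C(=O)c1ccc(OC)cc1)CC` gives 28000 nM
compound 2 `C=C(C(=O)c1ccc(OC)cc1)C(OC(C)=O)c1ccc([N+](=O)[O-])cc1` gives 6100 nM
compound 3 `C=C(C(=O)c1ccc(OC)cc1OC)C(OC(C)=O)c1ccc([N+](=O)[O-])cc1` gives 10400 nM

In a functional assay on MCF7 cells (Homo sapiens) for inhibition, read by XTT assay, with a stated time of 48 h (a higher number here means a weaker inhibitor, a lower number a stronger inhibitor), compound 3 gives 10400 nM and lies within the scatter of compound 2 (6100 nM), while its number is lower than that of compound 1 (28000 nM) by a margin beyond the scatter.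

Going on to compound 4 `C=C(C(=O)c1ccc(OC)cc1OC)C(OC(C)=O)c1ccccc1[N+](=O)[O-]` the change is 2-nitrophenyl in place of 4-nitrophenyl on a saturated chain carbon bound to a double-bonded chain carbon and an oxygen next to a carbonyl group and in words it is 2-nitrophenyl in place of 4-nitrophenyl on a saturated chain carbon bound to a double-bonded chain carbon and an oxygen next to a carbonyl group.

Within the data shown here, the one measured step is a 1.7-fold higher number from compound 2 to compound 3 (0.23 log units; within the scatter) for methoxy in place of hydrogen on an aromatic carbon, and it is a different change. Among the measured compounds shown here, no measured compound carries the 2-nitrophenyl group, so the data give no direction for this change. No step beyond the scatter is therefore expected, and the estimated step is a 1.2-fold lower number from compound 3 to compound 4 (0.06 log units; within the scatter) in size. Compound 4 is estimated at 9000 nM (expected range 3500 nM to 22000 nM).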

Compound 4, half-maximal inhibitory concentration: 70100 nM
Compound 4: middle estimate off by 7.8-fold (0.89 log units), on the low side; the measured number lies above the stated range.
By their numbers in this assay, from the lowest: compounds 2 and 3 (each within the scatter of the next); then compound 1; then compound 4.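

In this assay, 2-nitrophenyl in place of 4-nitrophenyl on the saturated chain carbon gives a 6.7-fold higher number from compound 3 to compound 4 (0.83 log units; beyond the scatter), so this position responds to the change, whereas the methoxy change elsewhere on the series gave only a 1.7-fold higher number from compound 2 to compound 3 (0.23 log units; within the scatter). The leaving and entering groups match in atoms and in every computed count, so a rearrangement of the same atoms alone is enough to separate compound 4 from compound 3. Nothing measured on these compounds accounts for the step.

As far as these compounds go, whether the same change gives a step of similar size on the core of compound 2, which lacks the second methoxy, remains open. Also open, from the compounds shown here alone, is how an amine or a carboxylic acid in place of the nitro group would behave on this phenyl ring.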